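Chloro on the pyridazine ring of a urea series

The source may hold more compounds than are shown below. What is called first, only, known or untested is meant among the compounds shown, and "the series" means these compounds.

Measured so far in an assay on HEK293 cells for inhibition of transient receptor potential cation channel subfamily V member 1 (Homo sapiens), read by FLIPR; a higher number here means a weaker inhibitor, a lower number a stronger inhibitor:
compound 1 `O=C(Nc1nc2ccc(F)cc2s1)N1CCN(c2ccc(Cl)nn2)CC1`, > 10000 nM
compound 2 `O=C(Nc1nc2ccc(F)cc2s1)N1CCN(c2cccnn2)CC1`, > 10000 nM
compound 3 `Cc1ccnnc1N1CCN(C(=O)Nc2ccc(C(C)(C)C)cc2)[C@H](C)C1`, 8.5 nM

The value of compound 1 in this assay is a limit of the assay, not a number. The value of compound 2 in this assay is likewise a limit. Within the data shown here, compound 3 gives the only numerical value, 8.5 nM. The difference between the core of compound 3 and the core of compound 2 is not broken down here.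

From compound 2 to compound 1 the change is chloro in place of hydrogen on an aromatic carbon, and the step is a step that the two limits leave unreadable from compound 2 to compound 1, as both values sit at the limit of > 10000 nM in this assay, at which 2 of the 3 values shown sit.

Compound 4 `Cc1cc(Cl)nnc1N1CCN(C(=O)Nc2ccc(C(C)(C)C)cc2)[C@H](C)C1` carries the same kind of change on the core of compound 3: chloro in place of hydrogen on an aromatic carbon. The place differs in being meta to a methyl group (1 heavy atom). Since the earlier step gives no readable size, the expectation for compound 4 rests on compound 3 at 8.5 nM and on a single chlorine entering. For compound 4 a step of a 1.2-fold higher number from compound 3 to compound 4 (0.07 log units; within the scatter) is estimated, within the usual scatter. Compound 4 is thus expected at about 10 nM, between 3 nM and 35 nM.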

Compound 4, half-maximal inhibitory concentration: 10 nM
The estimate for compound 4 equals the measured number at the digits printed; low and high end bracket the measured number.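

In this assay, chloro in place of hydrogen on an aromatic carbon, taking 4-methylpyridazin-3-yl to 6-chloro-4-methylpyridazin-3-yl, gives a 1.2-fold higher number from compound 3 to compound 4 (0.07 log units; within the scatter), so on this core the entering chlorine has no readable effect. The same kind of change on the core of compound 2 cannot be read, since compound 1 and compound 2 each give a limit of the assay and not a number: the limit of > 10000 nM in this assay, at which 2 of the 4 values shown sit.

The series therefore offers a single readable instance of this change, and it does not show whether the step carries from one core to another, nor why the number holds on the core of compound 3.

As far as these compounds go, whether a different group on the same aromatic carbon, such as methoxy, a dimethylamino group or a carboxylic acid, would also leave the number within the scatter stays open. Equally open, from the compounds shown here alone, is whether chloro would give a similar step on a further core whose values fall clear of the limit.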